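This account rests on a few compounds, and the source may have more. Where it says the series, first, only, none or still open, it means among the compounds named here.

Values in an ADME assay (liver) for metabolic stability, with Liver microsome (Rattus norvegicus) as the target, using microsomes (on this read-out higher numbers stand for fast clearance and lower numbers for slow clearance), so far:
- compound 1 `CN(C(=O)c1ccncc1)c1ccc(OCB2C=Cc3ccccc3N2)cc1` gives 115 mL/min/kg
- compound 2 `CN(C(=O)c1ccc2ncsc2c1)c1ccc(OCc2ccc3ccccc3c2)cc1` gives 48.3 mL/min/kg
- compound 3 `CN(C(=O)c1cc(-c2ccccc2)n[nH]1)c1ccc(OCB2C=Cc3ccccc3N2)cc1` gives 5.67 mL/min/kg

Compound 3 has the lowest number of the three. Compound 4 `CN(C(=O)c1cc(-c2ccccc2)n[nH]1)c1ccc(OCc2ccc3ccccc3c2)cc1` is compound 3 with one swap: a group of 10 heavy atoms (10 carbon; 2 six-membered aromatic rings of carbon only) in place of a group of 10 heavy atoms (8 carbon, 1 boron, 1 nitrogen; one six-membered non-aromatic ring with 2 hetero atoms, one six-membered aromatic ring of carbon only), on a saturated chain carbon bound to an oxygen on an aromatic ring (naphthalen-2-yl is the group that enters). Among the measured compounds shown here, the only measured step (a 20-fold lower number from compound 1 to compound 3 (1.31 log units; beyond the scatter)) is large, but it lies elsewhere, on a carbonyl carbon, so no measured step covers this swap. Compound 2, which already carries naphthalen-2-yl, stands at 48.3 mL/min/kg with a different group on the carbonyl carbon, so a moderate rise in this assay is expected, not a jump to that level. The estimated change is a 2.5-fold higher number from compound 3 to compound 4 (0.39 log units; beyond the scatter) and it remains uncertain. Compound 4 is estimated at 14 mL/min/kg (range 5 mL/min/kg to 40 mL/min/kg).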

Compound 4, clearance: 6.83 mL/min/kg
Compound 4: middle estimate off by 2.0-fold (0.31 log units), on the high side, within the range that was stated.
By their numbers in this assay, from the lowest: compounds 3 and 4 (each within the scatter of the next); then compound 2; then compound 1.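

In this assay, naphthalen-2-yl in place of the boron-containing group on the saturated chain carbon gives a 1.2-fold higher number from compound 3 to compound 4 (0.08 log units; within the scatter), which lies within the scatter, so the two groups cannot be told apart when 3-phenyl-1H-pyrazol-5-yl sits on the carbonyl carbon. With naphthalen-2-yl held fixed, 3-phenyl-1H-pyrazol-5-yl in place of 1,3-benzothiazol-6-yl gives a 7.1-fold lower number from compound 2 to compound 4 (0.85 log units; beyond the scatter), so the group on the carbonyl carbon also shifts the number with this partner. No evidence is available to explain either result. On these data alone, whether a much smaller group, such as methyl, would give a similar number on the saturated chain carbon remains open.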